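This account rests on a few compounds, and the source may have more. Where it says the series, first, only, none or still open, it means among the compounds named here.

Working notes on the series. Compound 3 `COc1cc(C(=O)N2CCN(C(=O)c3cc(OC)c(OC)c(OC)c3)C(COC(=O)NC(C)C(C)C)C2)cc(OC)c1OC` gives in a functional assay (Oryctolagus cuniculus) for inhibition of platelet-activating factor receptor (Cavia porcellus) (on this read-out lower numbers stand for stronger inhibition and higher numbers for weaker inhibition), a value of 80 nM. Among the single numbers in this assay that is the lowest; compound 1 `CCCCCC(=O)OCC1CN(C(=O)c2cc(OC)c(OC)c(OC)c2)CCN1C(=O)c1cc(OC)c(OC)c(OC)c1` gives 290 nM, and the step of a 3.6-fold lower number from compound 1 to compound 3 (0.56 log units; beyond the scatter) lies beyond the scatter. Compound 2 `COc1cc(C(=O)N2CCN(C(=O)c3cc(OC)c(OC)c(OC)c3)C(COC(=O)C(C)(C)C)C2)cc(OC)c1OC` gives 100 nM; 100 nM; 120 nM (3 entries) across its entries (the several entries of compound 2 in this assay, 100 nM; 100 nM; 120 nM (3 entries)), a set close enough to compound 3 that no order between the two can be claimed.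

Compound 4 `CCCCCCCCNC(=O)OCC1CN(C(=O)c2cc(OC)c(OC)c(OC)c2)CCN1C(=O)c1cc(OC)c(OC)c(OC)c1` is the next member, still unmeasured in this assay. It differs from compound 3 in one place: octyl in place of 1,2-dimethylpropyl on an amide-type nitrogen. For the measured compounds named here, no measured step swaps one alkyl group for another on the carbamate nitrogen, so the only guide is the pair of esters. There compound 1, carrying pentyl, sits above compound 2, carrying tert-butyl, by more than the scatter, which suggests a longer straight chain on the carbonyl side may run toward higher numbers. On that basis the expected step of a 1.9-fold higher number from compound 3 to compound 4 (0.27 log units; within the scatter) is a modest move upward, of a size that could fall within the scatter. Compound 4 is estimated at 150 nM in this assay, with a range of 60 nM to 400 nM.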

Compound 4, half-maximal inhibitory concentration: 370 nM
Compound 4: the middle estimate sits 2.5-fold (0.39 log units) below what was measured; measured number inside the range.
By their numbers in this assay, from the lowest: compound 3; then compounds 1 and 4 (each within the scatter of the next).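

In this assay, for the compounds shown here, the swap of octyl for 1,2-dimethylpropyl on an amide-type nitrogen gives a 4.6-fold higher number from compound 3 to compound 4 (0.67 log units; beyond the scatter) and is the first measured change of one alkyl group for another at this position, which shows that the read-out depends on the group carried there and not only on the carbamate link. The second step, a 1.3-fold higher number from compound 1 to compound 4 (0.11 log units; within the scatter) with octylamino in place of pentyl on a carbonyl carbon, stays within the scatter, so the lower number of compound 3 relative to compound 1 does not follow from an amino group at that place alone and holds only with (1,2-dimethylpropyl)amino among the compounds shown. Nothing measured here speaks to the cause of either step.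

Octyl and 1,2-dimethylpropyl differ both in chain length and in branching, so these compounds cannot separate the two. Open too, as far as these compounds go, is how a straight butyl chain on the same nitrogen, or a benzyl group or a chain ending in an amine, would read in this assay against compound 3 and compound 4.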